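From a nitrophenyl to a methoxyphenyl group

A few compounds are considered here, and "the series" means these few. Any claim that something is new, unique, unknown or untested is made for them only; others in the source may bear on it.

Within the data shown here, in a functional assay on HL-60 cells (Homo sapiens) for inhibition, read by CCK-8 assay, with a stated time of 48 h (on this read-out higher numbers stand for weaker inhibition and lower numbers for stronger inhibition), compound 2 `O=C(NCCNS(=O)(=O)c1ccc(-c2ccccc2Oc2ccc([N+](=O)[O-])c([N+](=O)[O-])c2)s1)Nc1ccc([N+](=O)[O-])cc1` gives 340 nM as the lowest number so far, and compound 1 `O=C(NCCNS(=O)(=O)c1ccc(-c2ccccc2Oc2ccc([N+](=O)[O-])c([N+](=O)[O-])c2)s1)Nc1cc(Cl)cc(Cl)c1` gives 2300 nM as the only other one. Compound 3 `COc1cccc(NC(=O)NCCNS(=O)(=O)c2ccc(-c3ccccc3Oc3ccc([N+](=O)[O-])c([N+](=O)[O-])c3)s2)c1` carries 3-methoxyphenyl in place of 4-nitrophenyl on an amide-type nitrogen. Among the measured compounds shown here, the one measured step at this place is a 6.8-fold lower number from compound 1 to compound 2 (0.83 log units; beyond the scatter) and it shows that a change there can move the number beyond the scatter. A rise of smaller size is expected here. The expected step is a 2.6-fold higher number from compound 2 to compound 3 (0.42 log units; beyond the scatter) in this assay as a higher number, meaning weaker inhibition. Compound 3 is estimated at 900 nM with a range from 300 nM to 2800 nM as the expected span.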

Compound 3, half-maximal inhibitory concentration: 6700 nM
The estimate for compound 3 lay 7.4-fold (0.87 log units) below the measured number, and the stated range ends below it.
By their numbers in this assay, from the lowest: compound 2; then compound 1; then compound 3.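

In this assay the group on this amide-type nitrogen sets the number over a wide span. Moving to 3-methoxyphenyl brings a 20-fold higher number from compound 2 to compound 3 (1.29 log units; beyond the scatter) and also a 2.9-fold higher number from compound 1 to compound 3 (0.46 log units; beyond the scatter) so compound 3 is the weakest of the three, and 4-nitrophenyl stays clearly ahead. Nothing given here explains this order.

Since compound 3 differs from compound 2 in both the substituent and where it sits, the two effects cannot be separated. 4-Methoxyphenyl or 3-nitrophenyl would separate them, while unsubstituted phenyl would give a plain reference point.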